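Replacing the piperazine carbamate with a cyclopropylmethyl group

The compounds below may be only part of what the source reports. "The series", "measured", "known", "first", "only" and "open" are said of these compounds alone.

Measured so far:
compound 1 `CCCCCC(=O)c1ccc(OCCCN2CCN(C(=O)OC)CC2)cc1`, 12000 nM
compound 2 `CCCCCC(=O)c1ccc(OCCCN2CCN(C(=O)OCC(C)C)CC2)cc1`, 3720 nM
compound 3 `CCCCCC(=O)c1ccc(OCCCN2CCN(C(=O)CSCC)CC2)cc1`, 22900 nM

In an assay on isolated protein for binding affinity to histamine H2 receptor (Homo sapiens) (a higher number here means a weaker inhibitor, a lower number a stronger inhibitor), compound 2 gives the lowest of the three numbers. Its nearest neighbour is compound 1, separated by a 3.2-fold lower number from compound 1 to compound 2 (0.51 log units; beyond the scatter), and the furthest is compound 3, separated by a 6.2-fold higher number from compound 2 to compound 3 (0.79 log units; beyond the scatter); both gaps lie beyond the scatter.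

Compound 4 `CCCCCC(=O)c1ccc(OCCCN2CCN(CC3CC3)CC2)cc1` is not yet measured. It differs from compound 2 as follows: cyclopropylmethyl in place of isobutoxycarbonyl on an amine nitrogen in a ring. Going by the values given here, no measured step removes the carbonyl from the ring nitrogen. The steps that come closest, a 3.2-fold lower number from compound 1 to compound 2 (0.51 log units; beyond the scatter) and a 6.2-fold higher number from compound 2 to compound 3 (0.79 log units; beyond the scatter), only exchange what the carbonyl carries, and they show that the group on the ring nitrogen moves this assay by modest amounts in either direction. Compound 4 is therefore expected to stay within a modest distance of compound 2, with no direction favoured, giving an estimated 1.3-fold higher number from compound 2 to compound 4 (0.13 log units; within the scatter). The estimate for compound 4 in this assay is 5000 nM, in a range from 800 nM to 25000 nM.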

Compound 4, inhibition constant: 18600 nM
Compound 4: middle estimate off by 3.7-fold (0.57 log units), on the low side, and the stated range covers the measured number.
By their numbers in this assay, from the lowest: compound 2; then compounds 1, 4 and 3 (each within the scatter of the next).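

In this assay, losing the carbonyl from the ring nitrogen is not neutral when compared with the isobutoxycarbonyl group: cyclopropylmethyl in its place gives a 5.0-fold higher number from compound 2 to compound 4 (0.70 log units; beyond the scatter). Against the two other carbonyl-bearing groups the same kind of exchange is not resolved, with a 1.6-fold higher number from compound 1 to compound 4 (0.19 log units; within the scatter) and a 1.2-fold lower number from compound 3 to compound 4 (0.09 log units; within the scatter), so a carbonyl on this nitrogen does not by itself set compounds apart, and only compound 2 stands clear of the other three. No supporting data are available to explain this pattern.

The compounds shown leave open whether the advantage of compound 2 belongs to its isobutyl chain or to the carbamate that carries it, a question that an isobutyl group on the ring nitrogen would address. Also open, as far as these compounds go, is whether a longer chain, such as hexyloxycarbonyl, would lower the number further.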